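Methoxymethyl in Place of Trifluoromethyl on a Silent Scaffold

This account rests on a few compounds, and the source may have more. Where it says the series, first, only, none or still open, it means among the compounds named here.

Of the compounds shown here, three built on one shared core have been measured. Compound 1 `O=C(O)CCCSCCN1C(=O)SC[C@@H]1/C=C/[C@@H](O)Cc1ccccc1` gives only a limit in an assay on CHO cells for displacement of a labelled ligand from prostaglandin E2 receptor EP1 subtype (Mus musculus), read by scintillation counting, with a stated time of 20 min (on this read-out lower numbers stand for stronger inhibition and higher numbers for weaker inhibition), where compound 1 shows > 10000 nM. Compound 2 `CCCc1cccc(C[C@H](O)/C=C/[C@H]2CSC(=O)N2CCSCCCC(=O)O)c1` likewise sits at a limit in this assay, at > 10000 nM. Compound 3 `O=C(O)CCCSCCN1C(=O)SC[C@@H]1/C=C/[C@@H](O)Cc1cccc(C(F)(F)F)c1` also stands at a limit in this assay, with > 10000 nM. Because (the limit of > 10000 nM in this assay, at which 3 of the 3 values shown sit), the three steps a step that the two limits leave unreadable from compound 1 to compound 2, a step that the two limits leave unreadable from compound 1 to compound 3 and a step that the two limits leave unreadable from compound 2 to compound 3 cannot be sized or given a direction.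

Compound 4 `COCc1cccc(C[C@H](O)/C=C/[C@H]2CSC(=O)N2CCSCCCC(=O)O)c1` has not yet been measured; it differs from compound 3 by methoxymethyl in place of trifluoromethyl on an aromatic carbon. Among the compounds with values here, no measured step speaks to this change, so no size or direction can be read from the data. Compound 4 is therefore expected to remain at the limit, the step that the limit leaves unreadable from compound 3 to compound 4 being expected to show no readable change. Compound 4 is estimated at 20000 nM, between 5000 nM and 100000 nM.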

Compound 4, inhibition constant: > 10000 nM
Compound 4: only a limit was reported; the forecaster's own chance of this, stated with the estimate: 85%; the middle value lies beyond the limit too.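

Compound 4 gives only a limit in this assay, at > 10000 nM. No step from compound 1, compound 2 or compound 3 to compound 4 can be read: the limit of > 10000 nM in this assay, at which 4 of the 4 values shown sit.

The compounds shown leave open whether any group on the aromatic ring gives a readable value.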